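Swapping one aromatic group on a shared core

The source may hold more compounds than are shown below. What is called first, only, known or untested is meant among the compounds shown, and "the series" means these compounds.

Compound 1 `CC1COC2(C=CC(=O)C=C2)N(c2ccccc2)C1=O`: 1220 nM
Compound 2 `O=C1C=CC2(C=C1)OCC(Cc1ccc(C(F)(F)F)cc1)C(=O)N2c1ccccc1`: 1650 nM

In a functional assay on BV-2 cells (Mus musculus), read by Griess assay, with a stated time of 24 h (on this read-out lower numbers stand for stronger inhibition and higher numbers for weaker inhibition), compound 2 gives 1650 nM, a value that cannot be told apart from that of compound 1 at 1220 nM. Compound 3 `Cc1cc(C)cc(CC2COC3(C=CC(=O)C=C3)N(c3ccccc3)C2=O)c1` keeps the shared core and differs in one group: 3,5-dimethylphenyl in place of 4-(trifluoromethyl)phenyl on a saturated chain carbon bound to a saturated ring carbon. Going by the values given here, only one measured step bears on this change: a 1.4-fold higher number from compound 1 to compound 2 (0.13 log units; within the scatter). Even that step, which adds a whole aromatic group, stays within the scatter, so swapping one aromatic group for another is expected to produce no step beyond the scatter. The expected step is a 1.1-fold lower number from compound 2 to compound 3 (0.04 log units; within the scatter). For compound 3 the estimated value is 1500 nM, with an expected range from 600 nM to 3800 nM.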

Compound 3, half-maximal inhibitory concentration: 1820 nM
Estimate against measurement, compound 3: 1.2-fold (0.08 log units) below, within the range that was stated.
By their numbers in this assay, from the lowest: compounds 1, 2 and 3 (each within the scatter of the next).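

In this assay, 3,5-dimethylphenyl in place of 4-(trifluoromethyl)phenyl gives a 1.1-fold higher number from compound 2 to compound 3 (0.04 log units; within the scatter) and so leaves the number within the scatter, whether the aromatic ring carries fluorine-bearing groups or methyl groups. Set against the plain methyl of compound 1, the same group gives a 1.5-fold higher number from compound 1 to compound 3 (0.17 log units; within the scatter) and so is also no clear step, which makes two different aromatic groups at this place indistinguishable from none. No measurement is available to explain this. On these data alone, whether an amine, a carboxylic acid or a longer chain at this place would move the number beyond the scatter remains open.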